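The source may report more compounds than this note shows. Statements on the series, on what has been measured and on what is new or still open speak of the compounds shown alone.

Of the compounds shown here, three sharing one core have been tested so far. Compound 1 `COc1cc(NC(=O)Nc2cc(Nc3ccc(OC)c(C)c3)ncn2)cc(OC)c1` gives 62% in a functional assay on PC-9 cells (Homo sapiens) for inhibition, read by MTT assay, with a stated time of 48 h, tested at 10 uM; on this read-out higher numbers stand for more inhibition at the one concentration tested (going by the name of the read-out) and lower numbers for less inhibition. Compound 2 `COc1cc(NC(=O)Nc2cc(Nc3ccc(F)c(Cl)c3)ncn2)cc(OC)c1` gives 77.5% in this assay, and compound 3 `COc1cc(NC(=O)Nc2cc(Nc3cc(I)ccc3OC)ncn2)cc(OC)c1` gives 91%. Compound 3 thus stands highest of the three, and both of its steps are beyond the scatter: a number 29 percentage points higher from compound 1 to compound 3 (beyond the scatter) and a number 13.5 percentage points higher from compound 2 to compound 3 (beyond the scatter).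

Compound 4 `COc1cc(NC(=O)Nc2cc(Nc3ccc(C)c(C)c3)ncn2)cc(OC)c1` is the next member. It differs from compound 3 in one place: 3,4-dimethylphenyl in place of 5-iodo-2-methoxyphenyl on a nitrogen on an aromatic ring.

All three measured steps change the same aryl group on this nitrogen, so all bear on the new step. The closest comparison is compound 1, whose 4-methoxy-3-methylphenyl resembles the entering 3,4-dimethylphenyl more than the 5-iodo-2-methoxyphenyl of compound 3 does, and the step of a number 29 percentage points higher from compound 1 to compound 3 (beyond the scatter) was modest but clearly beyond the scatter. A drop of similar size is therefore expected, and compound 4 is estimated to give 65% in this assay, between 45% and 85%, which means an expected step of a number 26 percentage points lower from compound 3 to compound 4 (beyond the scatter).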

Compound 4, a percentage reported as inhibition, at one concentration (the size of the read-out at that concentration, not a potency): 66%
Estimate against measurement, compound 4: 1 percentage points below; low and high end bracket the measured number.
By their numbers in this assay, from the lowest: compounds 1 and 4 (each within the scatter of the next); then compound 2; then compound 3.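

In this assay, the step with methyl in place of methoxy on an aromatic carbon is a number 4 percentage points higher from compound 1 to compound 4 (within the scatter), so this one exchange on the aryl group leaves the reading unchanged within the usual scatter. The 3,4-dimethylphenyl group also reads clearly lower than both halogen-bearing groups, with a number 11.5 percentage points lower from compound 2 to compound 4 (beyond the scatter) and a number 25 percentage points lower from compound 3 to compound 4 (beyond the scatter), so among these four compounds, both aryl groups with a halogen give higher numbers than both without one, and no compound goes against this. No measurement shown explains this difference.

From the compounds shown here alone, it remains open whether the iodine or the methoxy of the 5-iodo-2-methoxyphenyl group goes with the highest number, as the two appear only together. Also open, going by these compounds, is how a plain phenyl, or an aryl group carrying an amine or a carboxylic acid, would read on this nitrogen.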